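The source may report more compounds than this note shows. Statements on the series, on what has been measured and on what is new or still open speak of the compounds shown alone.

Measured so far:
compound 1 `C=C/C=C\[C@H](C)[C@H](OC(N)=O)[C@@H](C)[C@H](O)[C@@H](C)C/C(C)=C\[C@H](C)[C@@H](O)[C@@H](C)/C=C\CCc1ccsc1`: 4000 nM
compound 2 `C=C/C=C\[C@H](C)[C@H](OC(N)=O)[C@@H](C)[C@H](O)[C@@H](C)C/C(C)=C\[C@H](C)[C@@H](O)[C@@H](C)/C=C\CCc1ccc(Oc2ccccc2)cc1`: 10000 nM

Both compounds share a long chain and differ only in the aromatic group at its end. In a functional assay on MCF7 cells (Homo sapiens) for cytotoxicity (on this read-out higher numbers stand for weaker inhibition and lower numbers for stronger inhibition), compound 1 gives 4000 nM and stands lowest of the two numbers, meaning the stronger inhibition; compound 2 gives 10000 nM, a higher number that lies beyond the scatter of repeated measurements. Among the measured compounds shown here, no step between these two has been worked out, so the two values show only that the end group matters to some degree.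

Compound 3 `C=C/C=C\[C@H](C)[C@H](OC(N)=O)[C@@H](C)[C@H](O)[C@@H](C)C/C(C)=C\[C@H](C)[C@@H](O)[C@@H](C)/C=C\CCc1cccc(OC)c1` has not yet been measured. It differs from compound 1 in one place: 3-methoxyphenyl in place of thiophen-3-yl on a saturated chain carbon, two bonds along the chain from a double-bonded chain carbon. For the measured compounds named here, of the two measured compounds, the one with the larger six-membered aromatic end group gives the weaker inhibition, and 3-methoxyphenyl is also a six-membered aromatic ring, though a smaller group than the one in compound 2. The step from compound 1 is therefore expected to be small and, if anything, towards a higher number, a 1.4-fold higher number from compound 1 to compound 3 (0.14 log units; within the scatter). Compound 3 is estimated at 5500 nM in this assay, with a plausible range from 1800 nM to 17000 nM.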

Compound 3, half-maximal inhibitory concentration: 500 nM
For compound 3 the middle estimate is 11-fold (1.04 log units) above the measured one; measured number below the stated range.
By their numbers in this assay, from the lowest: compound 3; then compound 1; then compound 2.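

In this assay, the swap of thiophen-3-yl for 3-methoxyphenyl on a saturated chain carbon, two bonds along the chain from a double-bonded chain carbon, gives an 8.0-fold lower number from compound 1 to compound 3 (0.90 log units; beyond the scatter), a shift towards stronger inhibition that lies beyond the usual scatter of repeated measurements. Among the compounds shown here, the earlier pair suggested only that the end group matters to some degree, whereas here the two compounds differ in this one place, so the shift can be tied to this swap and shows that a six-membered aromatic ring of carbon only can be better tolerated at this position than thiophen-3-yl. No measurement at hand says why the swap lowers the number.

The swap changes the ring and brings in a methoxy group at the same time, so it remains open which of the two accounts for the step, and a plain phenyl ring at this position would separate them. As far as these compounds go, it also remains open how a hydroxyl group or an amine in place of the methoxy group, or a longer chain leading to the ring, would read in this assay.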